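Swapping Hydroxy for Chloro on a Shared Core

A few compounds are considered here, and "the series" means these few. Any claim that something is new, unique, unknown or untested is made for them only; others in the source may bear on it.

Of the compounds shown here, three built on one shared core have been tested in a functional assay on MDA-MB-231 cells (Homo sapiens) for inhibition, read by MTT assay, with a stated time of 48 h; a lower number here means a stronger inhibitor, a higher number a weaker inhibitor. Compound 1 `COc1cc(-c2cc(-c3ccc(N)cc3)nc(-c3ccccc3)n2)cc(OC)c1OC` gives 1010 nM. Compound 2 `COc1cc(-c2cc(-c3ccc(O)cc3O)nc(-c3ccccc3)n2)cc(OC)c1OC` gives 810 nM. Compound 3 `COc1cc(-c2cc(-c3ccc(O)cc3)nc(-c3ccccc3)n2)cc(OC)c1OC` gives 1600 nM, the highest of the three numbers, though the gaps to its neighbours are small: its nearest is compound 1, with a 1.6-fold higher number from compound 1 to compound 3 (0.20 log units; within the scatter), and its furthest is compound 2, with a 2.0-fold higher number from compound 2 to compound 3 (0.30 log units; within the scatter). All three numbers thus sit in one band that the scatter of repeated measurements can cover.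

Compound 4 `COc1cc(-c2cc(-c3ccc(Cl)cc3)nc(-c3ccccc3)n2)cc(OC)c1OC` has not yet been measured. It differs from compound 3 in one place: chloro in place of hydroxy on an aromatic carbon. Among the compounds with values here, none of the measured steps exchanges hydroxy for chloro, so no direct guide exists. What the measured steps do show is that changes to the group on this outer ring have so far moved the numbers little: a 1.6-fold higher number from compound 1 to compound 3 (0.20 log units; within the scatter) and a 1.2-fold lower number from compound 1 to compound 2 (0.10 log units; within the scatter) both stayed within the scatter. On that basis the step to compound 4 is expected to be small as well, with no clear direction, a 1.2-fold lower number from compound 3 to compound 4 (0.09 log units; within the scatter). Compound 4 is therefore estimated at 1300 nM, in a range from 500 nM to 3500 nM in this assay.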

Compound 4, half-maximal inhibitory concentration: > 25000 nM
Compound 4 ended at the assay's limit; the forecaster's own chance of this, stated with the estimate: 5%; middle value at least 19-fold (1.28 log units) from the limit.
By their numbers in this assay, from the lowest: compounds 2, 1 and 3 (each within the scatter of the next). At a limit, above all of these: compound 4.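

The number for compound 4 is a limit of the assay, not a measured value: the limit of > 25000 nM in this assay, at which 1 of the 4 values shown sits.

The earlier compounds shown here, with 4-aminophenyl, 2,4-dihydroxyphenyl and 4-hydroxyphenyl at this place, all sat within the scatter of one another, which gave no sign that a single exchange here could matter much, yet chloro in place of hydroxy gives an at least 15-fold higher number from compound 3 to compound 4 (1.19 log units; beyond the scatter), chloro in place of amino gives an at least 24-fold higher number from compound 1 to compound 4 (1.39 log units; beyond the scatter), and 4-chlorophenyl in place of 2,4-dihydroxyphenyl gives an at least 30-fold higher number from compound 2 to compound 4 (1.48 log units; beyond the scatter). This place on the ring, para to a large group, therefore does not accept every small group alike, and here one heavy atom exchanged for another separates compound 4 from the rest by a step far beyond the scatter.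

The compounds shown cannot tell whether the step reflects hydroxy leaving or chloro entering, and the full size of each step stays unknown. A fluoro or methyl group at the same place, or a plain phenyl ring with no group there, would help to separate these two readings.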